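The source may hold more compounds than are shown below. What is called first, only, known or untested is meant among the compounds shown, and "the series" means these compounds.

In a functional assay on HT-1080 cells (Homo sapiens) for cytotoxicity, read by MTT assay, with a stated time of 72 h (on this read-out lower numbers stand for stronger inhibition and higher numbers for weaker inhibition), three compounds sharing one core have been measured. Compound 1 `COc1ccc(/C=C2\CCC/C(=C\c3ccccc3Cl)C2=O)cc1OC` gives 6800 nM, compound 2 `COc1ccc(/C=C2\CCC/C(=C\c3ccc(Cl)cc3)C2=O)cc1OC` gives 4800 nM, and compound 3 `COc1ccc(/C=C2\CCC/C(=C\c3ccccc3Br)C2=O)cc1OC` gives 8400 nM. Compound 3 cannot be separated from the other two, with a 1.2-fold higher number from compound 1 to compound 3 (0.09 log units; within the scatter) and a 1.8-fold higher number from compound 2 to compound 3 (0.24 log units; within the scatter).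

The next compound, compound 4 `COc1ccc(/C=C2\CCC/C(=C\c3cccc(Br)c3)C2=O)cc1OC`, differs from compound 3 in one place, with 3-bromophenyl in place of 2-bromophenyl on a double-bonded chain carbon bound to a double-bonded ring carbon. Among the measured compounds shown here, no measured step moves a bromo group. For the measured compounds named here, the closest precedent is the change from 2-chlorophenyl to 4-chlorophenyl, a 1.4-fold lower number from compound 1 to compound 2 (0.15 log units; within the scatter). The exchange of chloro for bromo, a 1.2-fold higher number from compound 1 to compound 3 (0.09 log units; within the scatter), also bears on it. Both steps stay within the scatter, although neither tests the 3-substituted phenyl directly, so no change beyond the scatter is expected in this assay. The expected step is a 1.4-fold lower number from compound 3 to compound 4 (0.15 log units; within the scatter). Compound 4 is estimated at 6000 nM. The expected range for compound 4 runs from 3000 nM to 12000 nM.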

Compound 4, half-maximal inhibitory concentration: 5200 nM
For compound 4 the middle estimate is 1.2-fold (0.06 log units) above the measured one, and the stated range covers the measured number.
By their numbers in this assay, from the lowest: compounds 2, 4, 1 and 3 (each within the scatter of the next).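

The shift of the bromo group is now tested directly at this place, on a double-bonded chain carbon bound to a double-bonded ring carbon: in this assay, 3-bromophenyl in place of 2-bromophenyl gives a 1.6-fold lower number from compound 3 to compound 4 (0.21 log units; within the scatter). The 3-bromophenyl group, new in this series, also cannot be told apart from the two chlorophenyl groups, with a 1.1-fold higher number from compound 2 to compound 4 (0.03 log units; within the scatter) and a 1.3-fold lower number from compound 1 to compound 4 (0.12 log units; within the scatter). All four halophenyl compounds thus lie within the scatter of one another, and no measurement at hand bears on the reason for this.

The compounds shown carry only chloro or bromo on this phenyl ring. On these data alone, whether an amine or a carboxylic acid at this place would move the number beyond the scatter remains open.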